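The source may report more compounds than this note shows. Statements on the series, on what has been measured and on what is new or still open speak of the compounds shown alone.

Among the measured compounds shown here, in an assay on isolated protein for inhibition of Amine oxidase [flavin-containing] A (Homo sapiens), read by fluorescence, with stated times of 15 min and 20 min (a higher number here means a weaker inhibitor, a lower number a stronger inhibitor), compound 3 `CC(C)(C)c1cc(/C=C/C(=O)NCCC2CCN(Cc3ccccc3Cl)CC2)cc(C(C)(C)C)c1O` gives 72100 nM, the highest of the three numbers so far, though its neighbours sit close: compound 1 `CC(C)(C)c1cc(/C=C/C(=O)NCCC2CCN(Cc3ccccc3)CC2)cc(C(C)(C)C)c1O` gives 62300 nM and compound 2 `CC(C)(C)c1cc(/C=C/C(=O)NCCC2CCN(Cc3ccc(F)c(F)c3)CC2)cc(C(C)(C)C)c1O` gives 64500 nM, and the steps of a 1.2-fold higher number from compound 1 to compound 3 (0.06 log units; within the scatter) and a 1.1-fold higher number from compound 2 to compound 3 (0.05 log units; within the scatter) both stay within the scatter. Compound 4 `CC(C)(C)c1cc(/C=C/C(=O)NCCC2CCN(Cc3ccc(C#N)cc3)CC2)cc(C(C)(C)C)c1O` differs from compound 3 by 4-cyanophenyl in place of 2-chlorophenyl on a saturated chain carbon bound to an amine nitrogen in a ring. The measured steps that bear on such a swap of the aryl group are a 1.0-fold higher number from compound 1 to compound 2 (0.02 log units; within the scatter), a 1.2-fold higher number from compound 1 to compound 3 (0.06 log units; within the scatter) and a 1.1-fold higher number from compound 2 to compound 3 (0.05 log units; within the scatter), none of which reaches beyond the scatter. The expected step is therefore a 1.1-fold lower number from compound 3 to compound 4 (0.05 log units; within the scatter), that is, no movement beyond the scatter in either direction. Compound 4 is estimated at 65000 nM, with a range from 30000 nM to 140000 nM.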

Compound 4, half-maximal inhibitory concentration: 78200 nM
Beside the measured number, compound 4's estimate is 1.2-fold (0.08 log units) below it; measured number inside the range.
By their numbers in this assay, from the lowest: compounds 1, 2, 3 and 4 (each within the scatter of the next).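

In this assay, 4-cyanophenyl on a saturated chain carbon bound to an amine nitrogen in a ring shows a 1.1-fold higher number from compound 3 to compound 4 (0.04 log units; within the scatter), a 1.2-fold higher number from compound 2 to compound 4 (0.08 log units; within the scatter) and a 1.3-fold higher number from compound 1 to compound 4 (0.10 log units; within the scatter). Among the compounds shown here, a nitrile, absent from the earlier compounds, thus joins chloro and the two fluoro substituents without a step beyond the scatter, so the four compounds give no order at this position. Nothing available explains this flatness. Going by these compounds, whether a carboxylic acid or an amine on the phenyl ring would move the number stays open. So does the effect of a longer chain between the phenyl ring and the amine nitrogen.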